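The source may report more compounds than this note shows. Statements on the series, on what has been measured and on what is new or still open speak of the compounds shown alone.

Measured compounds:
Compound 1 `Cn1nc2c(=O)n(CC3(O)CCN(Cc4ccc(-c5ccco5)cc4Cl)CC3)cnc2c1-c1ccc(C(F)(F)F)cc1` gives 530 nM in an assay on isolated protein for inhibition of ubiquitin carboxyl-terminal hydrolase 7 (Homo sapiens), with stated times of 30 min and 2 h; on this read-out lower numbers stand for stronger inhibition and higher numbers for weaker inhibition.
Compound 2 `Cn1nc2c(=O)n(CC3(O)CCN(Cc4ccc(-c5ccco5)cc4Cl)CC3)cnc2c1-c1ccc(CNCCO)cc1` gives 8.2 nM in this assay.
Compound 3 `CC(=O)NCc1ccc(-c2c3ncn(CC4(O)CCN(Cc5ccc(-c6ccco6)cc5Cl)CC4)c(=O)c3nn2C)cc1` gives 46.1 nM in this assay.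

Compound 3 stands second highest of these three numbers, with a 5.6-fold higher number from compound 2 to compound 3 (0.75 log units; beyond the scatter) and an 11-fold lower number from compound 1 to compound 3 (1.06 log units; beyond the scatter). Compound 4 `Cn1nc2c(=O)n(CC3(O)CCN(Cc4ccc(-c5ccco5)cc4Cl)CC3)cnc2c1-c1ccc(OC(F)F)cc1` differs from compound 3 by difluoromethoxy in place of acetamidomethyl on an aromatic carbon. The step that bears most directly on this is an 11-fold lower number from compound 1 to compound 3 (1.06 log units; beyond the scatter), since compound 4, like compound 1, carries a small fluorine-containing group on that aromatic carbon. Compound 4 is therefore expected to move back toward compound 1, giving a step of a 6.5-fold higher number from compound 3 to compound 4 (0.81 log units; beyond the scatter) in this assay. The estimate for compound 4 is 300 nM, within a range from 100 nM to 900 nM.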

Compound 4, half-maximal inhibitory concentration: 179 nM
Compound 4: middle estimate off by 1.7-fold (0.22 log units), on the high side; the measured number falls inside the stated range.
By their numbers in this assay, from the lowest: compound 2; then compound 3; then compound 4; then compound 1.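

In this assay, the two fluorine-containing groups do not read the same at this position, with a 3.0-fold lower number from compound 1 to compound 4 (0.47 log units; beyond the scatter) when difluoromethoxy replaces trifluoromethyl. Difluoromethoxy still falls short of both nitrogen-containing groups, with a 3.9-fold higher number from compound 3 to compound 4 (0.59 log units; beyond the scatter) against acetamidomethyl and a 22-fold higher number from compound 2 to compound 4 (1.34 log units; beyond the scatter) against ((2-hydroxyethyl)amino)methyl, so across these four compounds both nitrogen-containing groups give the lowest numbers. No measurement here accounts for these differences. Going by these compounds, it remains open how a plain aminomethyl group or a carboxylic acid would compare at this position.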